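This account rests on a few compounds, and the source may have more. Where it says the series, first, only, none or still open, it means among the compounds named here.

In an assay on isolated protein for inhibition of tyrosine-protein kinase receptor UFO (Homo sapiens), with a stated time of 1.5 h (a lower number here means a stronger inhibitor, a higher number a weaker inhibitor), the three measured compounds stand as follows:
compound 1, `CNC1CCN(c2ccc3[nH]nc(-c4cnn(C)c4)c3c2)C1`, gives 432000 nM;
compound 2, `Cn1cc(-c2n[nH]c3ccc(N[C@H]4CCNC4)cc23)cn1`, gives 239000 nM;
compound 3, `Cn1cc(-c2n[nH]c3ccc(N)cc23)cn1`, gives 8910 nM.

Compound 3 has the lowest number of the three. Its nearest neighbour is compound 2 and its furthest is compound 1, whose step to compound 3 is a 48-fold lower number from compound 1 to compound 3 (1.69 log units; beyond the scatter); the step from compound 1 to compound 2 is a 1.8-fold lower number from compound 1 to compound 2 (0.26 log units; within the scatter). Compound 4, `Cn1cc(-c2n[nH]c3ccc(Nc4ccccc4)cc23)cn1`, is not yet measured. It differs from compound 3 by phenyl in place of hydrogen on a nitrogen on an aromatic ring. Within the data shown here, only one measured step bears on this change: the step from compound 2 to compound 3, a 27-fold lower number from compound 2 to compound 3 (1.43 log units; beyond the scatter), in which hydrogen replaced pyrrolidin-3-yl on that nitrogen. Among the measured compounds shown here, putting a group back on this nitrogen is therefore expected to raise the number, though phenyl is unlike pyrrolidin-3-yl and no measured compound carries an aromatic ring there, so the size is uncertain; the expected step is a 5.6-fold higher number from compound 3 to compound 4 (0.75 log units; beyond the scatter). Compound 4 is estimated at 50000 nM, between 8000 nM and 300000 nM.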

Compound 4, half-maximal inhibitory concentration: 580 nM
Beside the measured number, compound 4's estimate is 86-fold (1.94 log units) above it, outside the stated range (below it).
By their numbers in this assay, from the lowest: compound 4; then compound 3; then compounds 2 and 1 (each within the scatter of the next).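

On the nitrogen on an aromatic ring, adding a group does not by itself raise the number in this assay: phenyl in place of hydrogen gives a 15-fold lower number from compound 3 to compound 4 (1.19 log units; beyond the scatter), the opposite direction to the step seen with pyrrolidin-3-yl. What enters at this position therefore decides the direction of the change, at least for these two groups. Compound 4 also lies far from the compounds carrying saturated rings, with a 410-fold lower number from compound 2 to compound 4 (2.61 log units; beyond the scatter) and a 740-fold lower number from compound 1 to compound 4 (2.87 log units; beyond the scatter), and its steps to all three others are beyond the scatter, so it is the strongest of the four; nothing at hand bears on why phenyl has this effect.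

As far as these compounds go, whether a methoxy group or a carboxylic acid on the phenyl ring would keep the number this low remains open. So does whether a benzyl group or a pyridine ring on that nitrogen would do the same.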